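Iodine for hydrogen on the aryl ring of compound 1

The compounds below may be only part of what the source reports. "The series", "measured", "known", "first", "only" and "open" are said of these compounds alone.

Compound 1, `Cc1nc2c([nH]1)C(=O)/C(=N/c1ccccc1)C(Cl)=C2O`: 800 nM
Compound 2, `Cc1nc2c([nH]1)C(=O)/C(=N/c1ccc(Cl)cc1)C(Cl)=C2O`: 2800 nM; 2820 nM (2 entries)

In an ADME assay (Rattus norvegicus) for inhibition (a lower number here means a stronger inhibitor, a higher number a weaker inhibitor), compound 1 gives 800 nM, the only number shown for it, beside one further entry without a single number. Compound 2 gives 2800 nM; 2820 nM (2 entries) in this assay, and of this pair only what the two values show can be said: compound 2 is the weaker inhibitor, by more than the scatter.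

Compound 3, `Cc1nc2c([nH]1)C(=O)/C(=N/c1ccc(I)cc1)C(Cl)=C2O`, has not yet been measured. It differs from compound 1 by iodo in place of hydrogen on an aromatic carbon, which, cut one bond further out, reads phenyl to 4-iodophenyl. For the measured compounds named here, no measured step covers this change. Because the several entries of compound 2 in this assay, 2800 nM; 2820 nM (2 entries) shows compound 2 as a weaker inhibitor than compound 1, a step toward weaker inhibition beyond the scatter is expected, a 3.8-fold higher number from compound 1 to compound 3 (0.57 log units; beyond the scatter). Compound 3 is accordingly estimated at 3000 nM, with a range from 1000 nM to 9000 nM.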

Compound 3, half-maximal inhibitory concentration: 1000 nM
Compound 3: middle estimate off by 3.0-fold (0.48 log units), on the high side, within the range that was stated.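

In this assay, iodo in place of hydrogen on this aromatic carbon, para to a large group, gives a 1.3-fold higher number from compound 1 to compound 3 (0.10 log units; within the scatter), so a single iodine atom at this place leaves the read-out indistinguishable from that of the unsubstituted phenyl. Compound 2, with chloro at the same place, gives 2800 nM; 2820 nM (2 entries), a higher number than compound 3 at 1000 nM. The higher number therefore does not hold for both halogens at this place, and the contrast rests on a single compound, with the chloro result seen in the following: the several entries of compound 2 in this assay, 2800 nM; 2820 nM (2 entries)

Going by these compounds, how an amine or a carboxylic acid on this carbon would read remains open. The compounds shown also leave open whether iodo would give a similar result on another carbon of the aromatic ring.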